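The source may report more compounds than this note shows. Statements on the series, on what has been measured and on what is new or still open speak of the compounds shown alone.

In a functional assay on HUVEC cells (Homo sapiens) for inhibition, with a stated time of 4 days (on this read-out lower numbers stand for stronger inhibition and higher numbers for weaker inhibition), compound 2 `COc1ccc(C(N)=O)cc1/C=C/c1ccc(Cl)cc1` stands lowest of the three measured compounds at 87 nM against compound 1 `COc1ccc(C(C)=O)cc1COc1cccc(C)c1` at 2800 nM and compound 3 `COc1ccc(C(N)=O)cc1/C=C\c1ccc(Cl)cc1` at 2900 nM with both gaps beyond the scatter. For the measured compounds named here, the only measured step that changes a single place is a 33-fold higher number from compound 2 to compound 3 (1.52 log units; beyond the scatter) and it is large, but it concerns the configuration of the double bond alone, with the E form giving the lower number.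

Compound 4 `COc1ccc(C(N)=O)cc1/C=C/c1ccc(C(F)(F)F)cc1` keeps the E double bond and changes the other end of the molecule. The difference is trifluoromethyl in place of chloro on an aromatic carbon with trifluoromethyl in place of chloro on an aromatic carbon, para to a large group. Going by the values given here, no measured step touches this substituent, and the size of the configuration step does not carry over to it.

With the E double bond kept, compound 4 is expected to stay close to compound 2 at 87 nM rather than move towards compound 3 at 2900 nM on this evidence. The expected step is a 1.7-fold higher number from compound 2 to compound 4 (0.24 log units; within the scatter) in this assay which would be a small rise, not beyond the scatter. Compound 4 is estimated at 150 nM with 40 nM to 600 nM as the expected range.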

Compound 4, half-maximal inhibitory concentration: 880 nM
Beside the measured number, compound 4's estimate is 5.9-fold (0.77 log units) below it; measured number outside the range, above it.
By their numbers in this assay, from the lowest: compound 2; then compound 4; then compounds 1 and 3 (each within the scatter of the next).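

In this assay the substituent on an aromatic carbon para to a large group proves to be a second place in the series where the number moves, as trifluoromethyl in place of chloro gives a 10-fold higher number from compound 2 to compound 4 (1.00 log units; beyond the scatter) with the E double bond kept. The earlier single-place comparison concerned only the configuration of the double bond, with a 33-fold higher number from compound 2 to compound 3 (1.52 log units; beyond the scatter) as its measured step, and gave no reading of this substituent. The new step therefore shows that keeping the E double bond does not by itself hold the number near that of compound 2, while nothing at hand bears on why this substituent change raises the number.

As far as these compounds go, with only chloro and trifluoromethyl read at this place, it remains open whether hydrogen, fluoro, methoxy or an amine would stay near compound 2 or move towards compound 4. Also open, from the compounds shown here alone, are the effect of a carboxylic acid in place of the amide on the shared core and whether the trifluoromethyl step would hold with the double bond in the Z form.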